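The source may report more compounds than this note shows. Statements on the series, on what has been measured and on what is new or still open speak of the compounds shown alone.

Measured so far in a physicochemical assay for lipophilicity, read by HPLC, using the shake flask method; on this read-out lower numbers stand for lower lipophilicity and higher numbers for higher lipophilicity:
Compound 1 `CCCCCN(Cc1ccc(Cl)nc1)/C(C)=N/C#N`: 2.37
Compound 2 `CCCCN(Cc1ccc(Cl)nc1)/C(C)=N/C#N`: 2.13
Compound 3 `C=CCN(Cc1ccc(Cl)nc1)/C(C)=N/C#N`: 1.56

Compound 3, at 1.56, stands lowest of the three, and its gaps to the other two lie beyond the scatter. The next compound, not yet measured, is compound 4 `C/C(=N\C#N)NCc1ccc(Cl)nc1`. The change is hydrogen in place of allyl on an amine nitrogen.

Within the data shown here, three measured steps bear on this, all of them changes to the chain on that nitrogen. Trimming the end of the chain gave a number 0.24 log units lower from compound 1 to compound 2 (within the scatter), a step within the scatter. The two changes to allyl gave a number 0.81 log units lower from compound 1 to compound 3 (beyond the scatter) and a number 0.57 log units lower from compound 2 to compound 3 (beyond the scatter), both modest and beyond the scatter. All three steps point downward as the chain gets smaller, though the first cannot be told from no change. Among the measured compounds shown here, no measured compound carries hydrogen on that nitrogen, so the new step lies outside what has been seen and its size is uncertain. In this assay a further modest fall, beyond the scatter, is expected, with the estimated change being a number 0.66 log units lower from compound 3 to compound 4 (beyond the scatter). For compound 4 the estimated value is 0.9, with an expected range from 0.5 to 1.3.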

Compound 4, partition coefficient: 1.07
Estimate against measurement, compound 4: 0.17 log units below, within the range that was stated.
By their numbers in this assay, from the lowest: compound 4; then compound 3; then compounds 2 and 1 (each within the scatter of the next).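

In this assay the fall does not stop at the shortest chain: hydrogen in place of allyl on the amine nitrogen, which removes the chain altogether, gives a number 0.49 log units lower from compound 3 to compound 4 (beyond the scatter) and so extends the downward run seen among the chains. Among these compounds, the full change from a saturated chain to hydrogen yields the first large steps at this position, with a number 1.06 log units lower from compound 2 to compound 4 (beyond the scatter) for hydrogen in place of butyl and a number 1.30 log units lower from compound 1 to compound 4 (beyond the scatter) for hydrogen in place of pentyl, whereas the earlier steps were modest at most; compound 1 and compound 2 are the exception to a clean order, as they stay within the scatter of each other. No measurement at hand accounts for the size of these steps.

As far as these compounds go, whether the numbers fall evenly through short saturated chains such as methyl, ethyl or propyl remains open, as does the standing of a cyclopropylmethyl group or a chain ending in a hydroxyl or an amine on this nitrogen. All four compounds share one core, so whether hydrogen in place of these chains gives steps of similar size with another group in place of the chlorine is also unknown.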